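The source may report more compounds than this note shows. Statements on the series, on what has been measured and on what is new or still open speak of the compounds shown alone.

In a functional assay on GC-2 cells (Mus musculus) for cytotoxicity, read by MTT assay, with a stated time of 72 h (a higher number here means a weaker inhibitor, a lower number a stronger inhibitor), compound 1 `Nc1nc(Nc2ccccc2)sc1C(=O)c1cccnc1` gives 9500 nM. Compound 2 `Nc1nc(Nc2ccc(S(N)(=O)=O)cc2)sc1C(=O)c1cccnc1` gives > 30000 nM, which is a limit of the assay and not a number. For the measured compounds named here, putting sulfamoyl in place of hydrogen on an aromatic carbon produced an at least 3.1-fold higher number from compound 1 to compound 2 (0.49 log units; beyond the scatter), and this is the only measured step so far. Compound 3 `Nc1nc(Nc2ccc(S(N)(=O)=O)cc2)sc1C(=O)c1ccccc1[N+](=O)[O-]` keeps that sulfamoyl and instead carries 2-nitrophenyl in place of pyridin-3-yl on a carbonyl carbon. Going by the values given here, no step at this carbonyl carbon has been measured, so the sulfamoyl step bears on the new change only indirectly. With compound 2 at > 30000 nM, no step beyond the scatter is expected in this assay, and no direction can be favoured. The estimated change is an at least 1.0-fold lower number from compound 2 to compound 3 (0.02 log units; that floor lies within the scatter). For compound 3 the expected value is 28000 nM, within an estimated range from 8000 nM to 80000 nM.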

Compound 3, half-maximal inhibitory concentration: 9000 nM
Compound 3: the middle estimate sits 3.1-fold (0.49 log units) above what was measured; measured number inside the range.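

In this assay the carbonyl carbon proves to be a place where a change moves the reading: with the sulfamoyl kept, 2-nitrophenyl in place of pyridin-3-yl gives an at least 3.3-fold lower number from compound 2 to compound 3 (0.52 log units; beyond the scatter), a step towards a stronger inhibitor. For the compounds shown here, the only earlier step lay on an aromatic carbon and went the other way, so compound 3 shows that a sulfamoyl-bearing compound can still read as a measured number in this assay. On these data alone, the true size of the new step stays unknown, and the printed figure is only a floor, because compound 2 stands at a limit and not at a number: the limit of > 30000 nM in this assay, at which 1 of the 3 values shown sits.

Open, as far as these compounds go, is whether the nitro group or the carbon-only ring carries this step, since both arrive in one change. Also open, from the compounds shown here alone, is how an amine or a carboxylic acid on that ring would read.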